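Moving the Furan Attachment Point in a Cyanoacrylamide

The compounds below may be only part of what the source reports. "The series", "measured", "known", "first", "only" and "open" are said of these compounds alone.

Compound 1 `N#C/C(=C\c1c(F)c(F)c(F)c(F)c1F)C(=O)c1c[nH]c2ccccc12`: 18000 nM
Compound 2 `COc1ccc(CNC(=O)/C(C#N)=C/c2ccco2)cc1`: 31000 nM

Both compounds were tested in a functional assay on SW480 cells (Homo sapiens) for inhibition, read by MTT assay, with a stated time of 72 h; a higher number here means a weaker inhibitor of growth, a lower number a stronger inhibitor of growth. Compound 1 gives 18000 nM there, and compound 2 gives 31000 nM. These two numbers lie within the usual scatter of one another, so compound 2 stands level with compound 1, and neither can be called the stronger or the weaker growth inhibitor. Within the data shown here, the two compounds also share no common core, so no single structural step connects them.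

Compound 3 `COc1ccc(CNC(=O)/C(C#N)=C/c2ccoc2)cc1` is the next compound and has not yet been measured. It differs from compound 2 in one place: furan-3-yl in place of furan-2-yl on a double-bonded chain carbon bound to a double-bonded chain carbon. Every atom stays; only the point at which the furan joins the chain shifts. Among the measured compounds shown here, no measured pair shows what such a shift does here, so there is no recorded step to lean on. The expected step is therefore small and without a clear direction, a 1.1-fold higher number from compound 2 to compound 3 (0.05 log units; within the scatter), within the scatter. Compound 3 is estimated at 35000 nM in this assay, with a range from 12000 nM to 90000 nM.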

Compound 3, concentration for 50% growth inhibition: 8000 nM
For compound 3 the middle estimate is 4.4-fold (0.64 log units) above the measured one; measured number outside the range, below it.
By their numbers in this assay, from the lowest: compound 3; then compounds 1 and 2 (each within the scatter of the next).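

Moving the point at which the furan joins the chain, with every atom kept, is enough to alter growth inhibition in this assay and this change, furan-3-yl in place of furan-2-yl, gives a 3.9-fold lower number from compound 2 to compound 3 (0.59 log units; beyond the scatter) which is modest in size but lies beyond the usual scatter. Among these compounds, this is the first direct reading of this position, on a double-bonded chain carbon bound to a double-bonded chain carbon, and it shows that the result depends on how the ring is attached and not only on which atoms are present. Compound 1 and compound 2 could not show this, since they share no common core and no single step connects them, and no measurement shown here explains the difference between the two furans.

Going by these compounds, a single pair cannot show whether the step is particular to furan, so the effect of a thiophene or a pyridine ring at this place remains open. On these data alone, it is also open whether the step would persist if the methoxy group of compound 3 gave way to an amine or a carboxylic acid.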